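The compounds below may be only part of what the source reports. "The series", "measured", "known", "first", "only" and "open" are said of these compounds alone.

Compound 1 `COc1ccc(-c2cnc(NC(=O)c3ccccc3OC)n2C)cc1` is the starting point of this account. Compound 3 `COc1ccc(-c2cnc(NC(=O)c3ccccc3O)n2C)cc1` is the compound that is considered next to it. A second measured compound, compound 2 `COc1ccc(-c2cccc(NC(=O)c3ccc(F)cc3)n2)cc1`, stands alongside. In a toxicity assay on THP-1 cells (Homo sapiens) for inhibition (a higher number here means that more compound is tolerated, a lower number that less compound is tolerated), compound 1 gives > 100000 nM, which is a limit of the assay and not a number. In this assay compound 2 likewise gives > 100000 nM, also a limit. Among the measured compounds shown here, both measured values therefore sit at the limit of > 100000 nM in this assay, at which 2 of the 2 values shown sit, so compound 1 stands at the edge of what the assay can report, with no measured step available to show how any change moves the read-out. The change from compound 1 to compound 3 is hydrogen in place of methyl on an oxygen on an aromatic ring. With both neighbours at the limit, the expected step of a number no higher from compound 1 to compound 3 (the limit leaves the size open) is none beyond the scatter, and compound 3 is estimated at 100000 nM, between 50000 nM and 200000 nM.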

Compound 3, half-maximal cytotoxic concentration: > 100000 nM
Compound 3: a limit, no number; the forecaster's own chance of this, stated with the estimate: 85%; the middle value sits exactly at the limit.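

Compound 1 and compound 3 both stand at a limit of the assay, so no step can be read between them: the limit of > 100000 nM in this assay, at which 3 of the 3 values shown sit. The compounds shown leave open how far methoxy to hydroxy, or any other change, shifts the read-out in this assay at all.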